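The source may report more compounds than this note shows. Statements on the series, on what has been measured and on what is new or still open speak of the compounds shown alone.

- Compound 1 `COc1cc(N2C(=O)CC2c2ccc(SC)cc2)cc(OC)c1OC`: 67 nM
- Compound 2 `COc1cc(N2C(=O)C(Oc3ccccc3)C2c2ccc(SC)cc2)cc(OC)c1OC`: 152 nM

Among the measured compounds shown here, in a functional assay on MCF7 cells (Homo sapiens) for inhibition, read by resazurin assay, with a stated time of 72 h (a lower number here means a stronger inhibitor, a higher number a weaker inhibitor), compound 2 gives 152 nM, the higher of the two numbers so far. Compound 3 `COc1cc(N2C(=O)C(C3CC3)C2c2ccc(SC)cc2)cc(OC)c1OC` has cyclopropyl in place of phenoxy on a saturated ring carbon. For the measured compounds named here, only one measured step bears on this change, phenoxy in place of hydrogen at that carbon, which gave a 2.3-fold higher number from compound 1 to compound 2 (0.36 log units; beyond the scatter), a modest step. Going by the values given here, no measured compound carries cyclopropyl, so a modest step back towards compound 1 is only a tentative expectation in this assay. The expected change is a 1.5-fold lower number from compound 2 to compound 3 (0.18 log units; within the scatter), a somewhat lower number. For compound 3 the estimated value is 100 nM, within an expected range of 35 nM to 300 nM.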

Compound 3, half-maximal inhibitory concentration: 131 nM
For compound 3 the middle estimate is 1.3-fold (0.12 log units) below the measured one; the range from low to high includes it.
By their numbers in this assay, from the lowest: compounds 1, 3 and 2 (each within the scatter of the next, the first and the last beyond it).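

In this assay, cyclopropyl in place of phenoxy on this saturated ring carbon gives a 1.2-fold lower number from compound 2 to compound 3 (0.06 log units; within the scatter), so removing the oxygen and the six-membered aromatic ring leaves no clear difference. Cyclopropyl in place of hydrogen gives a 2.0-fold higher number from compound 1 to compound 3 (0.29 log units; within the scatter), so compound 3 cannot be separated from either neighbour, although compound 1 and compound 2 do differ from each other. No evidence on the cause of these results is available. Still open, from the compounds shown here alone, is how this carbon would tolerate an amine, a carboxylic acid or a longer carbon chain.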